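Swapping the aryl ketone for a thiophene

A few compounds are considered here, and "the series" means these few. Any claim that something is new, unique, unknown or untested is made for them only; others in the source may bear on it.

Of the compounds shown here, three built on one shared core have been tested in an assay on isolated protein for inhibition of histone deacetylase HD1B (Zea mays); a higher number here means a weaker inhibitor, a lower number a stronger inhibitor. Compound 1 `Cn1cc(/C=C/C(=O)c2cccc(Cl)c2)cc1/C=C/C(=O)NO` gives 31400 nM, compound 2 `Cn1cc(/C=C/C(=O)c2ccccc2F)cc1/C=C/C(=O)NO` gives 3400 nM, and compound 3 `Cn1cc(/C=C/C(=O)c2cccc(Br)c2)cc1/C=C/C(=O)NO` gives 480 nM, the lowest number of the three. The measured steps were a 9.2-fold lower number from compound 1 to compound 2 (0.97 log units; beyond the scatter), a 7.1-fold lower number from compound 2 to compound 3 (0.85 log units; beyond the scatter) and a 65-fold lower number from compound 1 to compound 3 (1.82 log units; beyond the scatter). Compound 4 `Cn1cc(/C=C/C(=O)c2ccsc2)cc1/C=C/C(=O)NO` carries thiophen-3-yl in place of 3-bromophenyl on a carbonyl carbon. Going by the values given here, the steps that bear on this are the two swaps of the whole aryl group on the carbonyl carbon, both modest in size, yet neither involves a five-membered ring, so the outcome is uncertain. With compound 3 already the lowest, a somewhat higher number is expected, and for compound 4 the expected change is a 6.3-fold higher number from compound 3 to compound 4 (0.80 log units; beyond the scatter). Compound 4 is estimated at 3000 nM, within a range from 500 nM to 15000 nM.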

Compound 4, half-maximal inhibitory concentration: 22600 nM
Compound 4: the middle estimate sits 7.5-fold (0.88 log units) below what was measured; the whole stated range lies below it.
By their numbers in this assay, from the lowest: compound 3; then compound 2; then compounds 4 and 1 (each within the scatter of the next).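

The thiophen-3-yl group falls well short of 3-bromophenyl (a 47-fold higher number from compound 3 to compound 4 (1.67 log units; beyond the scatter)) and of 2-fluorophenyl (a 6.6-fold higher number from compound 2 to compound 4 (0.82 log units; beyond the scatter)), yet it matches 3-chlorophenyl within the scatter (a 1.4-fold lower number from compound 1 to compound 4 (0.14 log units; within the scatter)). On this carbonyl carbon, then, a five-membered aromatic ring with a sulfur atom sits only with the weakest of the aryl groups shown. Nothing measured here explains these gaps.

Going by these compounds, whether a furan-3-yl or pyridine ring would behave the same remains open. So does whether a bromo group on the thiophene ring would bring the number back towards that of compound 3.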